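From 2,4-difluorophenyl to 2,5-difluorophenyl on the amide

A few compounds are considered here, and "the series" means these few. Any claim that something is new, unique, unknown or untested is made for them only; others in the source may bear on it.

In an ADME assay on LLC-MK2 cells (Macaca mulatta) for cytotoxicity, read by spectrophotometry and crystal violet staining, with a stated time of 4 days (on this read-out higher numbers stand for lower toxicity in this test and lower numbers for higher toxicity in this test), compound 1 (`CC(C)n1ncc2c(C(=O)Nc3cccc(F)c3)cc(-c3cccs3)nc21`) gives > 200000 nM, a limit of the assay and not a number. In this assay, compound 2 (`CC(C)n1ncc2c(C(=O)Nc3ccc(F)cc3F)cc(-c3cccs3)nc21`) gives > 200000 nM, also a limit and not a number. Compound 2 therefore stands at the limit of > 200000 nM in this assay, at which 2 of the 2 values shown sit.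

The next compound is compound 3 (`CC(C)n1ncc2c(C(=O)Nc3cc(F)ccc3F)cc(-c3cccs3)nc21`), with 2,5-difluorophenyl in place of 2,4-difluorophenyl on an amide-type nitrogen.

Within the data shown here, one measured step bears on this change: a step that the two limits leave unreadable from compound 1 to compound 2. It also moves a fluorine pattern on the same aryl group, but it has no readable size, so it offers only weak support. Neither measured compound gives a numerical reading in this assay. No step beyond the usual scatter is expected in either direction, and a further limit reading is the likeliest outcome.

The expected change is a number no higher from compound 2 to compound 3 (the limit leaves the size open).

For compound 3, the estimate is 200000 nM, with an expected range of 100000 nM to 300000 nM.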

Compound 3, half-maximal cytotoxic concentration: 100000 nM
The estimate for compound 3 lay 2.0-fold (0.30 log units) above the measured number; the range from low to high includes it.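

In this assay compound 3 gives 100000 nM, the first reading in this short series that is a number and not a limit, so at least one fluorine pattern on the aryl group on the amide-type nitrogen gives a value inside the readable range, which the other two values shown do not: the limit of > 200000 nM in this assay, at which 2 of the 3 values shown sit.

The change from 2,4-difluorophenyl to 2,5-difluorophenyl gives an at least 2.0-fold lower number from compound 2 to compound 3 (0.30 log units; that floor lies within the scatter), and the comparison with the 3-fluorophenyl amide, read as fluoro in place of hydrogen on an aromatic carbon, gives an at least 2.0-fold lower number from compound 1 to compound 3 (0.30 log units; that floor lies within the scatter). As far as these compounds go, both floors lie within the scatter and the true sizes stay open, while the step between the two limit compounds cannot be read, so no firm effect of the fluorine pattern on this read-out is established.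

How far the reading of compound 3 truly lies from those of compound 1 and compound 2 remains undetermined. Also open, from the compounds shown here alone, is how this read-out responds on the same amide position to a chloro or methoxy group, or to a carboxylic acid or a morpholine on the aryl ring.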